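Exchanging the Acyl Group of Compound 2

The source may hold more compounds than are shown below. What is called first, only, known or untested is meant among the compounds shown, and "the series" means these compounds.

Compound 2 `CC(C)c1ccccc1OS(=O)(=O)c1ccc(NC(=O)C(C)(C)C)cc1` is tested in a functional assay on HT-1080 cells (Homo sapiens) for antiproliferative activity, read by sulforhodamine B assay, with a stated time of 48 h (on this read-out higher numbers stand for weaker inhibition and lower numbers for stronger inhibition), where compound 2 gives 11000 nM. Compound 1 `CCCCCC(=O)Nc1cccc(S(=O)(=O)Oc2ccccc2C(C)C)c1` gives 11000 nM in this assay, the same number at the digits shown, so the two stand together at the highest value of the three measured; compound 3 `CC(C)(C)C(=O)Nc1ccc(S(=O)(=O)Oc2ccccc2I)cc1` gives 2600 nM. Within the data shown here, the only single-point step, a 4.2-fold lower number from compound 2 to compound 3 (0.63 log units; beyond the scatter), concerns a change on an aromatic carbon. Compound 4 `CCCCCNC(=O)Nc1ccc(S(=O)(=O)Oc2ccccc2C(C)C)cc1` differs from compound 2 elsewhere: pentylamino in place of tert-butyl on a carbonyl carbon. Among the measured compounds shown here, no measured step touches the carbonyl carbon, so the measured compounds give no ground for a shift beyond the scatter. Compound 4 is therefore expected to give about 11000 nM in this assay, between 3500 nM and 35000 nM. The estimated step is no change at the digits printed from compound 2 to compound 4 (within the scatter), expected as no change beyond the scatter.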

Compound 4, half-maximal inhibitory concentration: 4700 nM
Compound 4: the middle estimate sits 2.3-fold (0.37 log units) above what was measured; measured number inside the range.
By their numbers in this assay, from the lowest: compounds 3 and 4 (each within the scatter of the next); then compounds 1 and 2 (each within the scatter of the next).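

In this assay pentylamino in place of tert-butyl on the carbonyl carbon gives a 2.3-fold lower number from compound 2 to compound 4 (0.37 log units; beyond the scatter), the first measured sign that the number responds to a change at this position. The new group brings both a longer chain and one hydrogen-bond donor, and this single step cannot separate the two. Nothing available explains the shift. Still open, going by these compounds, is whether hexyl, which keeps a chain but has no amide-type nitrogen in that place, would give a similar number. Shorter ethylamino or ring-bearing cyclohexylamino could also show how far the chain or its shape matters.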